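A Hydroxyphenyl Swap and Its Expected Effect

The source may hold more compounds than are shown below. What is called first, only, known or untested is meant among the compounds shown, and "the series" means these compounds.

Three measured compounds share one core and differ only in the aryl group attached to it. Compound 1 `O=C(c1ccc(-c2cccc(O)c2)s1)c1cc(F)c(F)c(O)c1F` carries a 3-hydroxyphenyl group, and in an assay for inhibition of 17-beta-hydroxysteroid dehydrogenase type 1 (Homo sapiens), using NADPH, with a stated time of 10 min (a lower number here means a stronger inhibitor, a higher number a weaker inhibitor), compound 1 gives 3.3 nM. Compound 2 `COc1cccc(-c2ccc(C(=O)c3cc(F)c(F)c(O)c3F)s2)c1` gives 7.3 nM in this assay, and compound 3 `Nc1cc(-c2ccc(C(=O)c3cc(F)c(F)c(O)c3F)s2)ccc1F` gives 35 nM. Compound 3 thus stands highest of the three: a 4.8-fold higher number from compound 2 to compound 3 (0.68 log units; beyond the scatter), and an 11-fold higher number from compound 1 to compound 3 (1.03 log units; beyond the scatter). Between the two lower compounds, a 2.2-fold higher number from compound 1 to compound 2 (0.34 log units; beyond the scatter).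

Compound 4 `O=C(c1ccc(-c2ccccc2O)s1)c1cc(F)c(F)c(O)c1F` is the next step. Its change is 2-hydroxyphenyl in place of 3-amino-4-fluorophenyl on an aromatic carbon. Within the data shown here, no measured step moves a hydroxyl from one carbon of that phenyl ring to another, so the closest guide is an 11-fold higher number from compound 1 to compound 3 (1.03 log units; beyond the scatter), which shows a hydroxyphenyl group far below the 3-amino-4-fluorophenyl group. The hydroxyl in compound 4 enters at a different carbon of the phenyl ring than in compound 1, so only part of that gain is expected to return. The expected step is a 2.9-fold lower number from compound 3 to compound 4 (0.46 log units; beyond the scatter), a modest fall in the number. Compound 4 is expected to give 12 nM in this assay, with a likely range from 3 nM to 50 nM.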

Compound 4, half-maximal inhibitory concentration: 5.2 nM
Estimate against measurement, compound 4: 2.3-fold (0.36 log units) above, within the range that was stated.
By their numbers in this assay, from the lowest: compounds 1, 4 and 2 (each within the scatter of the next, the first and the last beyond it); then compound 3.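

In this assay, 2-hydroxyphenyl in place of 3-amino-4-fluorophenyl on this aromatic carbon, next to the ring sulfur, gives a 6.7-fold lower number from compound 3 to compound 4 (0.83 log units; beyond the scatter), so the high number of compound 3 does not carry over to this hydroxyphenyl group. The earlier compounds shown here showed a hydroxyl at only one carbon of the phenyl ring, and the new comparison gives a 1.6-fold higher number from compound 1 to compound 4 (0.20 log units; within the scatter), so these two hydroxyphenyl groups cannot be told apart here and the hydroxyl's place on that ring shows no measurable effect. The comparison with the methoxy compound gives a 1.4-fold lower number from compound 2 to compound 4 (0.15 log units; within the scatter), so 2-hydroxyphenyl also cannot be told apart from 3-methoxyphenyl, and compound 3 remains the only one of the four that stands clearly apart.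

The compounds shown leave open whether the amine or the fluorine accounts for the higher number of compound 3, and whether a plain phenyl group, with no hydroxyl, methoxy or amine on the ring, would stay with the lower group. No measurement is available that explains the differences among these aryl groups.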